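The compounds below may be only part of what the source reports. "The series", "measured", "known", "first", "only" and "open" are said of these compounds alone.

Compound 1 `Cc1cc2occ(-c3nc(-c4ccccc4)c(-c4ccccc4)n3-c3ccccc3Cl)c(=O)c2cc1Cl` is measured in a functional assay on MCF7 cells (Homo sapiens) for inhibition, read by MTT assay, with a stated time of 72 h (on this read-out lower numbers stand for stronger inhibition and higher numbers for weaker inhibition), where compound 1 gives 3120 nM. Among the three measured compounds it stands second highest: compound 2 `Cc1cc2occ(-c3nc(-c4ccccc4)c(-c4ccccc4)n3-c3ccc(Cl)c(Cl)c3)c(=O)c2cc1Cl` gives 1560 nM, and compound 3 `Cc1cc2occ(-c3nc(-c4ccccc4)c(-c4ccccc4)n3-c3ccc([N+](=O)[O-])cc3)c(=O)c2cc1Cl` gives 6250 nM. Compound 4 `Cc1cc2occ(-c3nc(-c4ccccc4)c(-c4ccccc4)n3-c3ccc(Br)cc3)c(=O)c2cc1Cl` has not yet been measured. It differs from compound 1 in one place: 4-bromophenyl in place of 2-chlorophenyl on an aromatic nitrogen. Two measured steps alter the same group on the aromatic nitrogen. The step of a 2.0-fold lower number from compound 1 to compound 2 (0.30 log units; within the scatter) stays within the scatter, and so does the step of a 2.0-fold higher number from compound 1 to compound 3 (0.30 log units; within the scatter). Between the two altered compounds, the step of a 4.0-fold higher number from compound 2 to compound 3 (0.60 log units; beyond the scatter) is modest. The entering group matches the leaving one in the counts shown, so any shift in this assay from compound 1 is expected to stay within the scatter, with no direction claimed. The expected step is a 1.1-fold lower number from compound 1 to compound 4 (0.05 log units; within the scatter). Compound 4 is therefore estimated at 2800 nM, with a range from 1200 nM to 6500 nM.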

Compound 4, half-maximal inhibitory concentration: 1560 nM
Compound 4: the middle estimate sits 1.8-fold (0.25 log units) above what was measured, within the range that was stated.
By their numbers in this assay, from the lowest: compounds 2, 4, 1 and 3 (each within the scatter of the next, the first and the last beyond it).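

The 4-bromophenyl group on the aromatic nitrogen cannot be told apart from the other halogen-bearing phenyl groups in this assay: the data show a 2.0-fold lower number from compound 1 to compound 4 (0.30 log units; within the scatter) and no change at the digits printed from compound 2 to compound 4 (within the scatter). Replacing the nitro group with bromo on the same phenyl ring gives a 4.0-fold lower number from compound 3 to compound 4 (0.60 log units; beyond the scatter), a modest step that places compound 4 with compound 2 as distinct from compound 3, although compound 1, also halogen-bearing, stays within the scatter of compound 3. Nothing measured here explains these steps.

As far as these compounds go, only halogens and a nitro group appear on this phenyl ring, so the effect of an amine, a carboxylic acid or a methoxy group remains open. Compound 1 and compound 4 also differ in both the halogen and its place on the ring, and these two changes cannot be separated.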